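The compounds below may be only part of what the source reports. "The series", "measured", "known", "first", "only" and "open" are said of these compounds alone.

Measured compounds:
Compound 1, `Cc1ccccc1-c1cccc(COc2ccc([C@H](CC(=O)O)c3nccn3C)cc2)c1`, gives 43 nM in an assay on CHO cells for agonist activity at Free fatty acid receptor 1 (Homo sapiens), read by luminescence, with a stated time of 20 s, in the presence of a further agent that is not named here; a higher number here means that more compound is needed for the effect, a lower number that less compound is needed.
Compound 2, `Cn1ccnc1[C@@H](CC(=O)O)c1ccc(OCc2cccc(-c3ccccc3S(C)(=O)=O)c2)cc1`, gives 23000 nM in this assay.
Compound 3, `COc1ccccc1-c1cccc(COc2ccc([C@H](CC(=O)O)c3nccn3C)cc2)c1`, gives 410 nM in this assay.

Compound 3 holds the second highest of these three numbers in this assay. Its nearest neighbour is shown by a 9.5-fold higher number from compound 1 to compound 3 (0.98 log units; beyond the scatter), a modest step; its furthest is shown by a 56-fold lower number from compound 2 to compound 3 (1.75 log units; beyond the scatter), a large one.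

The next compound, compound 4, `Cc1ccc(F)cc1-c1cccc(COc2ccc([C@H](CC(=O)O)c3nccn3C)cc2)c1`, differs from compound 3 in one place: 5-fluoro-2-methylphenyl in place of 2-methoxyphenyl on an aromatic carbon. For the measured compounds named here, two measured steps bear on this. The first is a 9.5-fold higher number from compound 1 to compound 3 (0.98 log units; beyond the scatter), which runs in the opposite direction to the present exchange of methoxy for methyl, so undoing it should pull the number back down by a similar modest amount. The second is a 530-fold higher number from compound 1 to compound 2 (2.73 log units; beyond the scatter), which shows that a different exchange on the same aromatic carbon moved the number far more, but that group plays no part here. Going by the values given here, no measured compound carries the fluorine, so its contribution is unknown and widens the range.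

Compound 4 is therefore expected at about 50 nM, within 15 nM to 170 nM. This corresponds to an expected 8.2-fold lower number from compound 3 to compound 4 (0.91 log units; beyond the scatter).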

Compound 4, half-maximal effective concentration: 36 nM
Estimate against measurement, compound 4: 1.4-fold (0.14 log units) above; low and high end bracket the measured number.
By their numbers in this assay, from the lowest: compounds 4 and 1 (each within the scatter of the next); then compound 3; then compound 2.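

The fluorine was the unknown in this exchange, and fluoro in place of hydrogen gives a 1.2-fold lower number from compound 1 to compound 4 (0.08 log units; within the scatter), so compound 1 and compound 4 cannot be told apart by this measurement. The fluorine on this ring therefore leaves no readable mark, and the step of an 11-fold lower number from compound 3 to compound 4 (1.06 log units; beyond the scatter) can be read mainly as the return from methoxy to methyl, running opposite to a 9.5-fold higher number from compound 1 to compound 3 (0.98 log units; beyond the scatter). The step of a 640-fold lower number from compound 2 to compound 4 (2.81 log units; beyond the scatter) extends the same picture: in these four compounds, the two rings carrying a methyl, in compound 1 and compound 4, give lower numbers than the rings carrying methoxy or methylsulfonyl, and neither compound 3 nor compound 2 goes against this.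

No measurement at hand explains why these groups give such different numbers. Going by these compounds, it remains open whether a chloro or a nitrile in place of the fluoro, or an ethyl in place of the methyl, would keep the number as low, and whether fluoro would also leave no readable mark on the rings of compound 2 and compound 3.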